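Three measured compounds and a fourth awaiting measurement

A few compounds are considered here, and "the series" means these few. Any claim that something is new, unique, unknown or untested is made for them only; others in the source may bear on it.

In an assay on isolated protein for inhibition of RAC-alpha serine/threonine-protein kinase (Homo sapiens), read by HTRF, tested at 10 uM (a lower number here means less inhibition, a higher number more inhibition at the concentration tested (going by the name of the read-out)), the measured compounds give:
compound 1 `Cc1cccc(N(C)c2cc(Nc3cccc(C(=O)N(CC(C)C)CC(C)C)c3)ncn2)c1`: 0%
compound 2 `COC[C@@H]1CCCN1C(=O)[C@@H]1CCCN1c1cc(Nc2cccc(OC)c2)nc(N)n1`: 0%
compound 3 `CN(CCCn1ccnc1)C(=O)[C@@H]1CCCN1c1nccc(Nc2ccccc2)n1`: 0%

Compound 3 stands level with compounds 1 and 2 at the digits shown; its nearest neighbour is compound 1 with no change within the scatter, and its furthest is compound 2, also with no change within the scatter. Compound 4 `CN(C)CC(C)(C)CNC(=O)[C@@H]1CCCN1c1nccc(Nc2ccccc2)n1` differs from compound 3 in one place: (2-((dimethylamino)methyl)-2-methylpropyl)amino in place of (3-(1H-imidazol-1-yl)propyl)(methyl)amino on a carbonyl carbon. Within the data shown here, no step between any two measured compounds is known, so there is no measured change on which to build. Compound 3 showing no inhibition, the step of a number 2 percentage points higher from compound 3 to compound 4 (within the scatter) is expected to stay within the scatter, with no direction beyond it. Compound 4 is therefore estimated at 2%, within -8% to 14%.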

Compound 4, a percentage reported as inhibition, at one concentration (the size of the read-out at that concentration, not a potency): 0%
Compound 4: the middle estimate sits 2 percentage points above what was measured; measured number inside the range.
By their numbers in this assay, from the lowest: compounds 1, 2, 3 and 4 (each within the scatter of the next).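

In this assay, among these compounds, putting (2-((dimethylamino)methyl)-2-methylpropyl)amino in place of (3-(1H-imidazol-1-yl)propyl)(methyl)amino on a carbonyl carbon gives no change at the digits printed from compound 3 to compound 4 (within the scatter) as the first step that can be read here. At this place, then, giving up the five-membered aromatic ring and gaining a hydrogen-bond donor leaves the reading unmoved, though both compounds show no inhibition, so the step cannot show how much this place matters. No measurement bears on why.

As far as these compounds go, whether a carboxylic acid or a longer chain on this carbonyl carbon would give any inhibition stays open.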